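From Nitrile to Fluorine on the Aryl Ring

The source may report more compounds than this note shows. Statements on the series, on what has been measured and on what is new or still open speak of the compounds shown alone.

Of the compounds shown here, three sharing one core have been measured in a functional assay (muscle tissue) with Cavia porcellus as the target; on this read-out higher numbers stand for an effect only at larger amounts of compound and lower numbers for an effect already at smaller amounts. Compound 1 `COC(=O)C1=C(C)N=C(C)/C(=C(\O)OC)C1c1ccc(Cl)cc1` gives 8130 nM. Compound 2 `COC(=O)C1=C(C)N=C(C)/C(=C(\O)OC)C1c1cccc(N(C)C)c1` gives 891 nM. Compound 3 `COC(=O)C1=C(C)N=C(C)/C(=C(\O)OC)C1c1cccc(C#N)c1` gives 34.7 nM, the lowest number of the three, and its steps to the other two both lie beyond the scatter: a 230-fold lower number from compound 1 to compound 3 (2.37 log units; beyond the scatter) and a 26-fold lower number from compound 2 to compound 3 (1.41 log units; beyond the scatter).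

Compound 4 `COC(=O)C1=C(C)N=C(C)/C(=C(\O)OC)C1c1cccc(F)c1` differs from compound 3 at one site: fluoro in place of cyano on an aromatic carbon. Within the data shown here, no measured pair shows a fluoro group at this position, so the only guidance is indirect. The step of a 26-fold lower number from compound 2 to compound 3 (1.41 log units; beyond the scatter) shows that exchanging the group at this aromatic carbon can move this assay by a large amount, and the step of a 230-fold lower number from compound 1 to compound 3 (2.37 log units; beyond the scatter) shows an even larger span across the measured set. Since the cyano group that accompanies the lowest number is removed in compound 4, the number is expected to rise, with a step of an 8.6-fold higher number from compound 3 to compound 4 (0.94 log units; beyond the scatter) in this assay, though a result close to compound 3 cannot be excluded. Compound 4 is therefore estimated at 300 nM in this assay, within a range from 60 nM to 1500 nM.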

Compound 4, half-maximal effective concentration: 20.9 nM
The estimate for compound 4 lay 14-fold (1.16 log units) above the measured number; measured number below the stated range.
By their numbers in this assay, from the lowest: compounds 4 and 3 (each within the scatter of the next); then compound 2; then compound 1.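

In this assay, a 1.7-fold lower number from compound 3 to compound 4 (0.22 log units; within the scatter) shows that the cyano group is not required for a low number at this aromatic carbon: the fluoro group, with no triple bond and no hydrogen-bond acceptor, gives a result that cannot be told apart from it. The large distance from the dimethylamino compound also persists with fluoro in place, at a 43-fold lower number from compound 2 to compound 4 (1.63 log units; beyond the scatter), and the exchange of 4-chlorophenyl for 3-fluorophenyl gives a 390-fold lower number from compound 1 to compound 4 (2.59 log units; beyond the scatter), so compound 3 and compound 4 together stand well apart from compound 1 and compound 2. Nothing measured here explains why the cyano and fluoro groups give results so close together.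

The compounds shown leave open whether other groups on this aromatic carbon, such as a methoxy group, a carboxylic acid or a plain hydrogen, would stay close to compound 3 and compound 4 or move toward compound 2. They also cannot separate the halogen from its place on the ring, since the step from 4-chlorophenyl to 3-fluorophenyl changes both at once, and a 3-chlorophenyl or 4-fluorophenyl group would be needed to divide the two.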